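The compounds below may be only part of what the source reports. "The series", "measured", "known", "first", "only" and "open" are said of these compounds alone.

Compound 1, `O=S(=O)(Cc1cccc(C(F)(F)F)c1)c1ccc(O)nn1`, in a functional assay on the whole organism for inhibition, with Rattus norvegicus as the target, at a dose of 20 mg/kg; a lower number here means a weaker effect, a higher number a stronger effect of the compound at the dose given: 88%
Compound 2, `O=S(=O)(Cc1cccc(F)c1F)c1ccc(O)nn1`, in this assay: 82%

For the measured compounds named here, compound 2 stands lowest of the two numbers, yet its only neighbour, compound 1, sits higher by an amount within the usual scatter, so the two cannot be told apart. Compound 3, `O=S(=O)(Cc1cccc(C(F)(F)F)c1F)c1ccc(O)nn1`, has not been measured. It differs from compound 2 by trifluoromethyl in place of fluoro on an aromatic carbon. Compound 1 also carries a trifluoromethyl and gives 88%, a number close to that of compound 2. The step from compound 2 to compound 3 is therefore expected to be small, a number 3 percentage points higher from compound 2 to compound 3 (within the scatter), none beyond the scatter. Compound 3 is estimated at 85%, between 70% and 95%.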

Compound 3, a percentage reported as inhibition, in the whole organism at one dose (the size of the read-out at that dose, not a potency): 61%
Compound 3: the middle estimate sits 24 percentage points above what was measured; the measured number lies below the stated range.
By their numbers in this assay, from the lowest: compound 3; then compounds 2 and 1 (each within the scatter of the next).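

In this assay, trifluoromethyl in place of fluoro, ortho to a fluoro group, proves no silent exchange: it brings a number 21 percentage points lower from compound 2 to compound 3 (beyond the scatter) at this position. Fluoro in place of hydrogen on a compound already carrying trifluoromethyl brings a number 27 percentage points lower from compound 1 to compound 3 (beyond the scatter) as well, so among these compounds the drop appears only where the two groups stand together. Nothing given here explains this drop.

From the compounds shown here alone, whether chloro, methyl or methoxy at this place would keep the effect stays open. So does whether the drop persists at other doses.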